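The source may report more compounds than this note shows. Statements on the series, on what has been measured and on what is new or still open speak of the compounds shown alone.

Compound 2, whose structure is `CCOc1ccc2c(NCCCN(C)C)ccnc2c1`, was tested in a functional assay on RKO cells (Homo sapiens) for cytotoxicity, read by MTT assay, with a stated time of 48 h (a lower number here means a stronger inhibitor, a higher number a weaker inhibitor), where compound 2 gives 5240 nM. That is the highest of the two numbers in hand. Within the data shown here, the only other measured compound is compound 1, with the structure `C=CCOc1ccc2c(NCCN(C)C)ccnc2c1`; in this assay compound 1 gives 1270 nM, and compound 2 therefore stands at a number that is beyond the scatter above that of compound 1. Among the measured compounds shown here, the two compounds differ in more than one place, so their pair gives no single step to read from.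

Compound 3 has the structure `C=CCOc1ccc2c(NCCCN(C)C)ccnc2c1`. Going from compound 2 to compound 3 makes one change: vinyl in place of methyl on a saturated chain carbon bound to an oxygen on an aromatic ring. For the measured compounds named here, no measured pair in this set shows that change alone, so any expectation for compound 3 rests on the numbers of compound 1 and compound 2 as they stand. Compound 1, which carries the allyloxy group, shows 1270 nM, and on that basis compound 3 is expected to give a lower number than compound 2, with the estimated step of a 1.9-fold lower number from compound 2 to compound 3 (0.27 log units; within the scatter). For compound 3 the expected value in this assay is 2800 nM, within a range from 1100 nM to 7000 nM.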

Compound 3, half-maximal inhibitory concentration: 3560 nM
Beside the measured number, compound 3's estimate is 1.3-fold (0.10 log units) below it; the measured number falls inside the stated range.
By their numbers in this assay, from the lowest: compound 1; then compounds 3 and 2 (each within the scatter of the next).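

Exchanging ethoxy for allyloxy, that is, vinyl in place of methyl on a saturated chain carbon bound to an oxygen on an aromatic ring, gives a 1.5-fold lower number from compound 2 to compound 3 (0.17 log units; within the scatter) in this assay and so does not separate the two groups at this place. Among these compounds, compound 3 also supplies the first readable step on the other side of the shared core, with the allyloxy group held constant: (dimethylamino)methyl in place of dimethylamino on a saturated chain carbon, two bonds along the chain from a nitrogen on an aromatic ring, gives a 2.8-fold higher number from compound 1 to compound 3 (0.45 log units; beyond the scatter) and is a modest step. Nothing in hand explains either result.

The compounds shown leave open whether a hydroxyl, a propargyloxy or a benzyloxy group at the oxygen would stand apart from ethoxy and allyloxy in this assay and whether the step on the amine side would recur with ethoxy in place of allyloxy. They also leave open how a longer chain, or a pyrrolidine in place of dimethylamino, would read in this cytotoxicity measurement.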